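Alkyl substitution and solubility: compounds 1 to 4

A few compounds are considered here, and "the series" means these few. Any claim that something is new, unique, unknown or untested is made for them only; others in the source may bear on it.

Measured in a physicochemical assay for solubility, in phosphate buffer, with a stated time of 18 h; a higher number here means a more soluble compound, a lower number a less soluble compound:
compound 1 `Cc1ncc2c(N)c(C#N)c(N)nc2n1`: 783000 nM
compound 2 `CC(C)Cc1ncc2c(N)c(C#N)c(N)nc2n1`: 268000 nM
compound 3 `CC(C)(C)c1ncc2c(N)c(C#N)c(N)nc2n1`: 37200 nM

Compound 3 stands lowest of the three in this assay; compound 2 is nearest and compound 1 furthest, both steps beyond the scatter. Compound 4 `Cc1nc(C(C)(C)C)nc2nc(N)c(C#N)c(N)c12` differs from compound 3 by methyl in place of hydrogen on an aromatic carbon. Going by the values given here, the steps that bear on this all add saturated carbon to the shared core: a 2.9-fold lower number from compound 1 to compound 2 (0.47 log units; beyond the scatter), a 21-fold lower number from compound 1 to compound 3 (1.32 log units; beyond the scatter) and a 7.2-fold lower number from compound 2 to compound 3 (0.86 log units; beyond the scatter), each lowering the number, the size broadly following how much carbon enters. A single methyl is a smaller addition than any of these, so only a modest drop, near the edge of the scatter, is expected: a 2.1-fold lower number from compound 3 to compound 4 (0.32 log units; beyond the scatter). Compound 4 is accordingly estimated at 18000 nM, within 7000 nM to 45000 nM.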

Compound 4, solubility: 37000 nM
The estimate for compound 4 lay 2.1-fold (0.31 log units) below the measured number; the range from low to high includes it.
By their numbers in this assay, from the lowest: compounds 4 and 3 (each within the scatter of the next); then compound 2; then compound 1.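

In this assay, methyl in place of hydrogen on this aromatic carbon, next to the ring nitrogen, gives a 1.0-fold lower number from compound 3 to compound 4 (0.00 log units; within the scatter) and so leaves compound 3 and compound 4 within the scatter of each other. The earlier steps shown here that added saturated carbon all lay beyond the scatter, so compound 4 goes against that pattern. No supporting data on hand account for this result.

Open, on these data alone, is whether an ethyl group, a longer chain or an amine on this same aromatic carbon would also stay within the scatter of compound 3. Also open, as far as these compounds go, is whether methyl here gives the same result with a group other than tert-butyl on the core.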